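The source may report more compounds than this note shows. Statements on the series, on what has been measured and on what is new or still open speak of the compounds shown alone.

Measured in a functional assay on SW-620 cells (Homo sapiens) for inhibition, read by MTT assay, with a stated time of 72 h; on this read-out lower numbers stand for stronger inhibition and higher numbers for weaker inhibition:
compound 1, `Cc1ccc2nc(-c3ccc(NCc4cn(Cc5cc(=O)oc6cc(O)ccc56)nn4)cc3)sc2c1`: 90000 nM
compound 2, `Cc1ccc2c(Cn3cc(CNc4ccc(-c5nc6ccc(C)cc6s5)cc4)nn3)cc(=O)oc2c1`: >= 100000 nM
compound 3, `Cn1c(-c2cn(Cc3cc(=O)oc4cc(O)ccc34)nn2)nc2ccccc21`: > 100000 nM

The value of compound 2 is a limit of this assay, not a number (the limit of >= 100000 nM in this assay, at which 1 of the 3 values shown sits). The value of compound 3 is likewise a limit (the limit of > 100000 nM in this assay, at which 1 of the 3 values shown sits). From compound 1 to compound 2 the change is methyl in place of hydroxy on an aromatic carbon, and the step is an at least 1.1-fold higher number from compound 1 to compound 2 (0.04 log units; that floor lies within the scatter). The cores of compound 1 and compound 3 differ, but that difference is not broken down here. Compound 4, `Cc1ccc2c(Cn3cc(-c4nc5ccccc5n4C)nn3)cc(=O)oc2c1`, arises from compound 3 by the same change at the same place, (methyl in place of hydroxy on an aromatic carbon). For compound 4 the expected step is a number no higher from compound 3 to compound 4 (the limit leaves the size open), resting on the earlier step of an at least 1.1-fold higher number from compound 1 to compound 2 (0.04 log units; that floor lies within the scatter) and on the limit of > 100000 nM in this assay, at which 1 of the 3 values shown sits, at which compound 3 stands. Compound 4 is estimated at 100000 nM, expected between 50000 nM and 200000 nM.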

Compound 4, half-maximal inhibitory concentration: > 100000 nM
Compound 4: only a limit was reported; the forecaster's own chance of this, stated with the estimate: 85%; the middle value sits exactly at the limit.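

Compound 3 and compound 4 both stand at limits of the assay, not numbers, so no step can be read between them. The compounds shown leave open whether methyl in place of hydroxy changes inhibition in this pair.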